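This account rests on a few compounds, and the source may have more. Where it says the series, first, only, none or still open, it means among the compounds named here.

Compound 1, `Cc1ccc(-c2cn(C/C=C3\OC(=O)C(OCc4ccccc4)=C3OCc3ccccc3)nn2)cc1`, was studied in a functional assay on HCT-116 cells (Homo sapiens) for antiproliferative activity, read by MTT assay, with a stated time of 72 h; on this read-out lower numbers stand for stronger inhibition and higher numbers for weaker inhibition. In this assay compound 1 gives > 100000 nM, which is a limit of the assay rather than a number. Compound 2, `O=C1O[C@H]([C@@H](O)Cn2cc(-c3cccc(O)c3)nn2)C(OCc2ccccc2)=C1OCc1ccccc1`, gives 42900 nM in this assay. Compound 3, `O=C1O/C(=C\Cn2cc(-c3cc(C(F)(F)F)cc(C(F)(F)F)c3)nn2)C(OCc2ccccc2)=C1OCc1ccccc1`, gives > 100000 nM in this assay, again a limit and not a number. The setting for any new compound is the limit of > 100000 nM in this assay, at which 2 of the 3 values shown sit. Compound 4, `COc1ccccc1-c1cn(C/C=C2\OC(=O)C(OCc3ccccc3)=C2OCc2ccccc2)nn1`, has yet to be measured in this assay; it differs from compound 1 by 2-methoxyphenyl in place of 4-methylphenyl on an aromatic carbon. For the measured compounds named here, no pair of measured compounds differs in a single place, so nothing here shows how such a change moves the result. The move a number no higher from compound 1 to compound 4 (the limit leaves the size open) is expected to be none beyond the usual scatter of this assay. Compound 4 is estimated at 100000 nM, between 30000 nM and 300000 nM.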

Compound 4, half-maximal inhibitory concentration: > 100000 nM
Compound 4 was reported as a limit (the forecaster's own chance of this, stated with the estimate: 70%); the middle value sits exactly at the limit.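

Compound 1 and compound 4 are both reported only as limits and not as numbers, so no step can be read between them. The compounds shown leave open how 2-methoxyphenyl and 4-methylphenyl compare in this assay.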